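The source may report more compounds than this note shows. Statements on the series, on what has been measured and on what is new or still open speak of the compounds shown alone.

Three compounds sharing one core have been measured in a functional assay on HCT-116 cells (Homo sapiens) for antiproliferative activity, read by MTT assay, with a stated time of 72 h; a higher number here means a weaker inhibitor, a lower number a stronger inhibitor:

compound 1 `COc1ccc(N2CCN(C(=S)SCc3ccc4nc(N)nc(N)c4c3)CC2)cc1`: 2270 nM
compound 2 `Cc1ccc(N2CCN(C(=S)SCc3ccc4nc(N)nc(N)c4c3)CC2)c(C)c1`: 4070 nM
compound 3 `Nc1nc(N)c2cc(CSC(=S)N3CCN(c4ccccc4Cl)CC3)ccc2n1`: 5490 nM

Compound 3 stands at the upper end of these three numbers. The nearest value gives a 1.3-fold higher number from compound 2 to compound 3 (0.13 log units; within the scatter), while the furthest gives a 2.4-fold higher number from compound 1 to compound 3 (0.38 log units; beyond the scatter).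

The next compound is compound 4 `Nc1nc(N)c2cc(CSC(=S)N3CCN(c4ccc(Cl)c(Cl)c4)CC3)ccc2n1`, which has 3,4-dichlorophenyl in place of 2-chlorophenyl on an amine nitrogen in a ring. Among the measured compounds shown here, no measured compound carries this group, so the evidence is indirect. The measured steps that bear on the change are those that exchange the group at this same place. Besides the two already given, there is a 1.8-fold higher number from compound 1 to compound 2 (0.25 log units; within the scatter). Two of the three steps stay within the scatter, and the only one beyond it is modest. On that basis, no step beyond the scatter is expected in this assay, in either direction, although the data cannot show what the added chlorine does here.

The estimate for compound 4 is 3700 nM, with an expected range of 1500 nM to 8500 nM. This estimate corresponds to an expected 1.5-fold lower number from compound 3 to compound 4 (0.17 log units; within the scatter).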

Compound 4, half-maximal inhibitory concentration: 6680 nM
The estimate for compound 4 lay 1.8-fold (0.26 log units) below the measured number; the measured number falls inside the stated range.
By their numbers in this assay, from the lowest: compounds 1, 2, 3 and 4 (each within the scatter of the next, the first and the last beyond it).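

In this assay the exchange of 2-chlorophenyl for 3,4-dichlorophenyl on the amine nitrogen gives a 1.2-fold higher number from compound 3 to compound 4 (0.09 log units; within the scatter) and so does not separate the two compounds, and the exchange of 2,4-dimethylphenyl for the same group gives a 1.6-fold higher number from compound 2 to compound 4 (0.22 log units; within the scatter) and does not separate those two either. The added chlorine therefore leaves no readable mark at this position, and compound 2, compound 3 and compound 4 form one group of closely similar numbers, with compound 1 the only one that stands apart from any of them, as the modest 2.9-fold higher number from compound 1 to compound 4 (0.47 log units; beyond the scatter) shows, the widest step yet seen at this place. No measurement available here accounts for these small differences or for the position of compound 1.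

The compounds shown carry only phenyl rings with chlorine, methyl or methoxy groups on this nitrogen, so they leave open whether a carboxylic acid or an amine on that phenyl ring would move the number beyond the scatter. They also leave open whether a plain alkyl chain in place of the phenyl ring would be tolerated in this assay.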